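Notes on the step from compound 3 to compound 4

The compounds below may be only part of what the source reports. "The series", "measured", "known", "first", "only" and "open" are said of these compounds alone.

Measured so far in a physicochemical assay for lipophilicity; on this read-out lower numbers stand for lower lipophilicity and higher numbers for higher lipophilicity
- compound 1 `C/C=C/C=C/C(=O)OCCC` gives 2.31
- compound 2 `C/C=C/C=C/C(=O)OC(C)C` gives 2.26
- compound 3 `C/C=C/C=C/C(=O)OCCC(C)C` gives 3.04

Compound 3 stands highest of the three at 3.04 in this assay with compound 1 and compound 2 both lower beyond the scatter. Not yet measured is compound 4 `C=CCOC(=O)/C=C/C=C/C` and the change leading to it is vinyl in place of isobutyl on a saturated chain carbon bound to an oxygen next to a carbonyl group in words vinyl in place of isobutyl on a saturated chain carbon bound to an oxygen next to a carbonyl group.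

Among the measured compounds shown here, two measured steps bear on this. The more useful one is a number 0.73 log units higher from compound 1 to compound 3 (beyond the scatter) and it shows that a change at the chain end can move the number in this assay beyond the scatter. The other is a number 0.05 log units lower from compound 1 to compound 2 (within the scatter) and it gives no sign that propyl and isopropyl separate on this read-out. In the new step the entering group is smaller than the leaving one, the reverse of the direction in the first of these steps. A fall beyond the scatter is therefore expected, close in size to that step or somewhat larger. The expected move is a number 0.99 log units lower from compound 3 to compound 4 (beyond the scatter) on this estimate. For compound 4 the estimated value is 2.05 with an expected range from 1.75 to 2.35 in this assay for now.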

Compound 4, partition coefficient: 2.24
Compound 4: middle estimate off by 0.19 log units, on the low side, within the range that was stated.
By their numbers in this assay, from the lowest: compounds 4, 2 and 1 (each within the scatter of the next); then compound 3.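

In this assay, vinyl in place of isobutyl on a saturated chain carbon bound to an oxygen next to a carbonyl group gives a number 0.80 log units lower from compound 3 to compound 4 (beyond the scatter) and shows that changes at this position can move the number downward beyond the scatter, whereas the earlier step beyond the scatter ran upward. Allyl in place of isopropyl gives a number 0.02 log units lower from compound 2 to compound 4 (within the scatter) and vinyl in place of ethyl gives a number 0.07 log units lower from compound 1 to compound 4 (within the scatter), so the double bond in compound 4 does not separate it from compound 1 or compound 2, and among the four compounds only compound 3 stands apart on this read-out. No measured evidence bears on the reason for these steps.

The compounds shown leave open whether the step seen with isobutyl belongs to that branched group alone or would also appear with a longer unbranched chain such as butyl. They also leave open how far the number would move with an amine or a hydroxyl group at this position, and whether a benzyl group would stand with compound 3 or with the other three compounds.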